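This account rests on a few compounds, and the source may have more. Where it says the series, first, only, none or still open, it means among the compounds named here.

In a functional assay on MDA-MB-231 cells (Homo sapiens) for cytotoxicity, read by MTT assay, with a stated time of 72 h (a higher number here means a weaker inhibitor, a lower number a stronger inhibitor), compound 1 `CN1CCN(CCCCCCn2c3c(c4ccccc42)C(=O)c2c[n+]([O-])c4ccccc4c2C3=O)CC1` gives 2400 nM, compound 2 `O=C1c2c[n+]([O-])c3ccccc3c2C(=O)c2c1c1ccccc1n2Cc1cn(C[C@@H](O)CO)nn1` gives 670 nM and compound 3 `O=C1c2c[n+]([O-])c3ccccc3c2C(=O)c2c1c1ccccc1n2CCCCN1CCNCC1` gives 3310 nM. Compound 3 has the highest number of the three: the smaller gap is a 1.4-fold higher number from compound 1 to compound 3 (0.14 log units; within the scatter), the larger is a 4.9-fold higher number from compound 2 to compound 3 (0.69 log units; beyond the scatter). Compound 4 `O=C1c2c[n+]([O-])c3ccccc3c2C(=O)c2c1c1ccccc1n2CCN1CCCC1` differs from compound 3 by pyrrolidin-1-yl in place of 2-(piperazin-1-yl)ethyl on a saturated chain carbon, two bonds along the chain from an aromatic nitrogen. Of the measured steps only a 1.4-fold higher number from compound 1 to compound 3 (0.14 log units; within the scatter) concerns a change in the chain bearing a non-aromatic nitrogen ring, and it stayed within the scatter; a 3.6-fold lower number from compound 1 to compound 2 (0.55 log units; beyond the scatter) and a 4.9-fold higher number from compound 2 to compound 3 (0.69 log units; beyond the scatter) involve the 1-(2,3-dihydroxypropyl)-1H-1,2,3-triazol-4-yl group and do not apply. No step beyond the scatter is therefore expected, with a slight lean to a lower number. Compound 4 is estimated at 2500 nM, range 1000 nM to 6500 nM, an expected step of a 1.3-fold lower number from compound 3 to compound 4 (0.12 log units; within the scatter).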

Compound 4, half-maximal inhibitory concentration: 630 nM
The estimate for compound 4 lay 4.0-fold (0.60 log units) above the measured number; the whole stated range lies above it.
By their numbers in this assay, from the lowest: compounds 4 and 2 (each within the scatter of the next); then compounds 1 and 3 (each within the scatter of the next).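

In this assay, the chain on the aromatic nitrogen can shift the number beyond the scatter: a 5.3-fold lower number from compound 3 to compound 4 (0.72 log units; beyond the scatter) and a 3.8-fold lower number from compound 1 to compound 4 (0.58 log units; beyond the scatter), whereas the earlier step between compound 1 and compound 3 stayed within it. The 2-(pyrrolidin-1-yl)ethyl chain of compound 4 also sits level with the 1-(2,3-dihydroxypropyl)-1H-1,2,3-triazol-4-yl group of compound 2, with a 1.1-fold lower number from compound 2 to compound 4 (0.03 log units; within the scatter). No evidence at hand bears on this result.

Ring and chain length change together in compound 4, so their shares in the step remain open. A pyrrolidine ring on a butyl chain, or a piperazine ring on an ethyl chain, would separate them.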